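This account rests on a few compounds, and the source may have more. Where it says the series, first, only, none or still open, it means among the compounds named here.

Measured compounds in a functional assay on SK-OV-3 cells (Homo sapiens) for inhibition, read by sulforhodamine B assay, with a stated time of 48 h; a higher number here means that more compound is tolerated, a lower number that less compound is tolerated:
- compound 1, `COc1cc(-c2cc(/C=C/C(=O)c3ccc(N)cc3)[nH]n2)cc(OC)c1OC`: compound 1 gives 28900 nM
- compound 2, `COc1ccc(C(=O)/C=C/c2cc(-c3cc(OC)c(OC)c(OC)c3)n[nH]2)cc1OC`: compound 2 gives 27600 nM
- compound 3, `COc1ccc(-c2cc(/C=C/C(=O)c3ccc(N)cc3)[nH]n2)cc1OC`: compound 3 gives 41300 nM

The three measured compounds sit close together in this assay. The step from compound 3 to compound 1 is a 1.4-fold lower number from compound 3 to compound 1 (0.16 log units; within the scatter), made by methoxy in place of hydrogen on an aromatic carbon. The step from compound 1 to compound 2 is a 1.0-fold lower number from compound 1 to compound 2 (0.02 log units; within the scatter). Compound 2 and compound 3 are not compared by a single counted change; the difference between the two cores is not broken down here, and the two values alone show no separation that exceeds the usual scatter.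

Compound 4, `COc1cc(C(=O)/C=C/c2cc(-c3cc(OC)c(OC)c(OC)c3)n[nH]2)cc(OC)c1OC`, is not yet measured in this assay. Among the measured compounds shown here, it differs from compound 2 by methoxy in place of hydrogen on an aromatic carbon, which is the same change as the one from compound 3 to compound 1: the place lines of the two changes agree word for word, the entering methoxy standing ortho to a methoxy group, meta to a large group and meta to a methoxy group in both cases. On that single precedent, the step from compound 2 to compound 4 is expected to be a 1.2-fold lower number from compound 2 to compound 4 (0.08 log units; within the scatter), on the grounds that the same change gave a 1.4-fold lower number from compound 3 to compound 1 (0.16 log units; within the scatter) and that this step lay within the scatter. Compound 4 is accordingly estimated at 23000 nM, with a range from 10000 nM to 55000 nM to allow for the scatter of this kind of measurement.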

Compound 4, concentration lethal to 50% of the cells: 33400 nM
The estimate for compound 4 lay 1.5-fold (0.16 log units) below the measured number; measured number inside the range.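

In this assay, methoxy in place of hydrogen on an aromatic carbon, ortho to a methoxy group, now gives a 1.2-fold higher number from compound 2 to compound 4 (0.08 log units; within the scatter). Set beside the earlier reading of the same change on another core, the two steps do not separate: the same change on two cores in this assay, a 1.4-fold lower number (0.16 log units; within the scatter) from compound 3 to compound 1 and a 1.2-fold higher number (0.08 log units; within the scatter) from compound 2 to compound 4, 1.7-fold (0.24 log units) apart, within the scatter of two such steps. Within these two pairs, the change therefore carries from one core to the other with no difference that can be told from the scatter, but this does not show that its effect is the same on both cores, nor that it has any effect on either, and two pairs give no basis for a rule across the series.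

Still open, from the compounds shown here alone, is whether a different group at this place, such as hydroxy, chloro, an amine, a carboxylic acid or the longer ethoxy chain, would give a step beyond the scatter in this assay. Also open, going by these compounds, is whether the methoxy change would stay within the scatter on cores other than these two, or in other cell lines.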